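Swapping an aryl amide for a benzyl amide

The compounds below may be only part of what the source reports. "The series", "measured", "known", "first", "only" and "open" are said of these compounds alone.

Compound 1 `O=C(/C=C/c1coc2cc(O)ccc2c1=O)NCc1ccc(F)cc1` gives 357000 nM in an ADME assay on HepG2 2.2.15 cells (Homo sapiens) for cytotoxicity, read by MTT assay, with stated times of 48 h and 9 days; a higher number here means that more compound is tolerated, a lower number that less compound is tolerated.
Compound 2 `COc1ccc2c(=O)c(/C=C/C(=O)Nc3ccc(Cl)cc3)coc2c1` gives 272000 nM in this assay.
Compound 3 `Cc1ccc(CNC(=O)/C=C/c2coc3cc(O)ccc3c2=O)cc1` gives 501000 nM in this assay.

All three compounds share the same chromone-based core, shown in their structures, carrying an unsaturated amide side chain. Compound 2 gives the smallest of the three numbers, but its gaps to compound 1 and to compound 3 both fall within the scatter of this assay, so the three compounds are tolerated to a similar degree. For the measured compounds named here, the one step between compounds that differ in a single place, a 1.4-fold higher number from compound 1 to compound 3 (0.15 log units; within the scatter), is also within the scatter.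

The unmeasured compound 4 `COc1ccc2c(=O)c(/C=C/C(=O)NCc3ccccc3)coc2c1` differs from compound 2 in one place: benzyl in place of 4-chlorophenyl on an amide-type nitrogen. Going by the values given here, no measured pair shows this exact change, so no step bears on it directly. What the numbers do show is that compound 1 and compound 3, both carrying a benzyl-type group on the amide nitrogen, sit within the scatter of compound 2, which carries an aryl group there. The expectation is therefore a step of a 1.2-fold higher number from compound 2 to compound 4 (0.07 log units; within the scatter), none beyond the scatter. Compound 4 is estimated at 320000 nM in this assay, with a range from 160000 nM to 640000 nM.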

Compound 4, half-maximal cytotoxic concentration: 376000 nM
For compound 4 the middle estimate is 1.2-fold (0.07 log units) below the measured one; low and high end bracket the measured number.
By their numbers in this assay, from the lowest: compounds 2, 1, 4 and 3 (each within the scatter of the next).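

Swapping 4-chlorophenyl for benzyl on the amide-type nitrogen gives a 1.4-fold higher number from compound 2 to compound 4 (0.14 log units; within the scatter) in this assay and is the first change at this position with both sides of the pair measured. Both groups hold one six-membered aromatic ring of carbon only and neither has a hydrogen-bond donor or acceptor, so the pair compares a chlorine-bearing aryl group with an all-carbon benzyl group, and in these cells the two cannot be told apart at this position. Nothing measured here gives a reason for the size of this step.

Going by these compounds, one pair speaks only for the core of compound 2, so it remains open whether the same swap would give a similar step on a different core. On these data alone, it also remains open how this position would respond to groups further from these two, such as phenethyl, which has a longer chain, or a benzyl group carrying an amine or a carboxylic acid.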